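The source may hold more compounds than are shown below. What is called first, only, known or untested is meant among the compounds shown, and "the series" means these compounds.

Measured so far in a physicochemical assay for solubility, read by nephelometry; on this read-out lower numbers stand for lower solubility and higher numbers for higher solubility:
- compound 1 `CC1(C)C(=O)N(c2ccc(SC(F)(F)F)cc2)C(=O)N1Cc1ccnc(C(=O)O)c1`: 0.142 ug/mL
- compound 2 `CC1(C)C(=O)N(c2ccc(SC(F)(F)F)cc2)C(=O)N1Cc1ccnc(Nc2ccccc2)c1`: < 0.025 ug/mL (a limit of the assay)

Compound 2 reads < 0.025 ug/mL, which is a limit of the assay and not a number. Its standing is therefore known only as the limit of < 0.025 ug/mL in this assay, at which 1 of the 2 values shown sits.

The next compound to be read is compound 3 `CCc1cc(CN2C(=O)N(c3ccc(SC(F)(F)F)cc3)C(=O)C2(C)C)ccn1`, which carries ethyl in place of anilino on an aromatic carbon, next to the ring nitrogen: ethyl in place of anilino on an aromatic carbon.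

Among the measured compounds shown here, only one measured step bears on this change: an at least 5.6-fold lower number from compound 1 to compound 2 (0.75 log units; beyond the scatter). There anilino entered in place of carboxy, and the step lies beyond the scatter. Its size is open-ended, so it gives a direction more than a firm magnitude. Compound 3 no longer has the anilino, and a move back toward higher numbers is expected, although ethyl is not the carboxy of compound 1.

The expected change in this assay is an at least 2.4-fold higher number from compound 2 to compound 3 (0.38 log units; beyond the scatter), a modest step upward. For compound 3 the estimated value is 0.06 ug/mL, with an expected range of 0.025 ug/mL to 0.2 ug/mL. Another reading at the limit remains possible.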

Compound 3, solubility: < 0.022 ug/mL
Compound 3 gave a limit, no number; the forecaster's own chance of this, stated with the estimate: 35%; at least 2.7-fold (0.43 log units) between middle value and limit.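

In this assay compound 3 reads < 0.022 ug/mL and that is a limit of the assay, not a number. Among the compounds shown here, at this aromatic carbon next to the ring nitrogen, ethyl in place of carboxy gives an at least 6.4-fold lower number from compound 1 to compound 3 (0.80 log units; beyond the scatter) and anilino in place of carboxy gave an at least 5.6-fold lower number from compound 1 to compound 2 (0.75 log units; beyond the scatter) in the same direction, so two very different replacements of carboxy now point downward, and carboxy remains the only group here with a number on this read-out. The step between compound 2 and compound 3 cannot be read, as both ends are limits, but removing the six-membered aromatic ring and the hydrogen-bond donor of anilino did not bring the reading up to a number, and no order between anilino and ethyl follows from these values.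

As far as these compounds go, whether the number of compound 1 depends on the carboxylic acid itself, or would also appear with a primary amide, an amine or a hydroxymethyl at this carbon, remains open. From the compounds shown here alone, how far compound 2 and compound 3 lie under their limits also remains open, and a more sensitive read-out would be needed to rank them.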